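The compounds below may be only part of what the source reports. "The series", "measured", "known", "first", "only" and "open" are said of these compounds alone.

Measured in a physicochemical assay for lipophilicity, measured as octanol-water partition; a higher number here means a more lipophilic compound, a lower number a more polar compound:
- compound 1 `O=C(NNc1ccnc2cc(Cl)ccc12)c1ccccc1/N=C/c1ccc(Cl)c(Cl)c1`: 6.22
- compound 2 `O=C(NNc1ccnc2cc(Cl)ccc12)c1ccccc1/N=C/c1ccc(Br)cc1`: 5.76
- compound 3 `COc1ccc(/C=N/c2ccccc2C(=O)NNc2ccnc3cc(Cl)ccc23)cc1`: 5

Compound 3 has the lowest number of the three in this assay, and the gap to each of the others is clear. The next structure is compound 4 `O=C(NNc1ccnc2cc(Cl)ccc12)c1ccccc1/N=C/C=C/c1ccccc1`, which differs from compound 3 at one place: 2-phenylethenyl in place of 4-methoxyphenyl on a carbon with a double bond to nitrogen. Put simply, this is 2-phenylethenyl in place of 4-methoxyphenyl on a carbon with a double bond to nitrogen.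

All three measured steps swap the group at this same place. The two that end at compound 3 are the closest guides: a number 0.76 log units lower from compound 2 to compound 3 (beyond the scatter), and a number 1.22 log units lower from compound 1 to compound 3 (beyond the scatter). The third, a number 0.46 log units lower from compound 1 to compound 2 (beyond the scatter), shows that a modest shift is also possible between two other groups. Among the compounds with values here, no measured compound carries 2-phenylethenyl, so the evidence is indirect. Like the groups of compound 1 and compound 2, however, the entering group has no oxygen, so a modest rise looks most likely. The expected step is a number 0.50 log units higher from compound 3 to compound 4 (beyond the scatter). For compound 4 the estimated value is 5.5, with an expected range from 5.1 to 6.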

Compound 4, partition coefficient: 5.54
Compound 4: middle estimate off by 0.04 log units, on the low side; measured number inside the range.
By their numbers in this assay, from the lowest: compound 3; then compounds 4 and 2 (each within the scatter of the next); then compound 1.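

In this assay, 4-methoxyphenyl and 2-phenylethenyl have the same number of heavy atoms, yet the swap on the carbon with a double bond to nitrogen gives a clear step (a number 0.54 log units higher from compound 3 to compound 4 (beyond the scatter)), so a change in atoms at this position can shift the number even when that count stays the same. Compared with the two halogen-bearing groups, 2-phenylethenyl gives two different outcomes: the step from 4-bromophenyl (a number 0.22 log units lower from compound 2 to compound 4 (within the scatter)) does not separate the pair, while the step from 3,4-dichlorophenyl (a number 0.68 log units lower from compound 1 to compound 4 (beyond the scatter)) does. Nothing measured here explains why these steps take the sizes they do.

The compounds shown leave open how this position would respond to an amine, a carboxylic acid or a longer carbon chain. They also leave open whether these steps would hold with a change elsewhere on the shared core.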